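Fluorine on the outer ring of compound 1

The source may report more compounds than this note shows. Statements on the series, on what has been measured and on what is new or still open speak of the compounds shown alone.

Compound 1 `CN(C)CCCCCSC1=Nc2ccccc2C(CC(=O)NCc2ccc(F)cc2)N1c1ccc(-c2ccccc2)cc1` gives 27400 nM in an assay on cells for inhibition of Voltage-dependent T-type calcium channel subunit alpha-1G (Homo sapiens), read by patch clamp (on this read-out lower numbers stand for stronger inhibition and higher numbers for weaker inhibition), the highest number among the three measured compounds. Compound 2 `O=C(CC1c2ccccc2N=C(SCCCCCN2CCCC2)N1c1ccc(-c2ccccc2)cc1)NCc1ccc(F)cc1` gives 15000 nM and compound 3 `O=C(CC1c2ccccc2N=C(SCCCCCN2CCCC2)N1c1ccccc1)NCc1ccc(F)cc1` gives 13500 nM. The step from compound 1 to compound 2 was a 1.8-fold lower number from compound 1 to compound 2 (0.26 log units; within the scatter), and that from compound 2 to compound 3 was a 1.1-fold lower number from compound 2 to compound 3 (0.05 log units; within the scatter); both fall within the scatter.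

Compound 4 `CN(C)CCCCCSC1=Nc2ccccc2C(CC(=O)NCc2ccc(F)cc2)N1c1ccc(-c2ccc(F)cc2)cc1` differs from compound 1 by fluoro in place of hydrogen on an aromatic carbon, on an aromatic carbon of a six-membered aromatic ring of carbon only; cut one bond further out, the change reads phenyl to 4-fluorophenyl. For the measured compounds named here, no measured step adds a fluoro to this ring. The closest guide is the step from compound 2 to compound 3, which removed the whole phenyl from the same part of the shared core and still gave a 1.1-fold lower number from compound 2 to compound 3 (0.05 log units; within the scatter). A single fluoro on that ring is therefore expected to give no step beyond the scatter, a 1.1-fold lower number from compound 1 to compound 4 (0.04 log units; within the scatter). Compound 4 is estimated at 25000 nM, with a range from 10000 nM to 60000 nM.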

Compound 4, half-maximal inhibitory concentration: 400 nM
Compound 4: middle estimate off by 63-fold (1.80 log units), on the high side; the measured number lies below the stated range.
By their numbers in this assay, from the lowest: compound 4; then compounds 3, 2 and 1 (each within the scatter of the next, the first and the last beyond it).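

In this assay, the change from phenyl to 4-fluorophenyl gives a 69-fold lower number from compound 1 to compound 4 (1.84 log units; beyond the scatter), so a single fluoro, on an aromatic carbon para to a large group, moves the number far more than any earlier change did. The earlier step that removed the whole phenyl gave only a 1.1-fold lower number from compound 2 to compound 3 (0.05 log units; within the scatter), so the mere presence of this ring showed little, whereas a substituent on it can matter greatly, at least with the dimethylamino chain end of compound 1. Nothing available explains the size of this step.

Going by these compounds, it remains open whether the step is specific to fluoro or would also appear with chloro, methyl or methoxy at this place. On these data alone, it is also open whether the same 4-fluorophenyl gives a comparable step with the pyrrolidin-1-yl chain end of compound 2.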